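Pentyl to 2-phenylethenyl on a shared pyranone-free core

A few compounds are considered here, and "the series" means these few. Any claim that something is new, unique, unknown or untested is made for them only; others in the source may bear on it.

Measured so far in a functional assay on SK-BR-3 cells (Homo sapiens) for cytotoxicity, read by MTT assay, with a stated time of 72 h; a lower number here means that less compound is needed, a higher number that more compound is needed for the effect:
compound 1, `COc1ccc(Nc2cc(C3CCCCC3)oc(=O)c2)cc1`, gives 5.29 uM.
compound 2, `CCCCCc1cc(Nc2ccc(OC)cc2)cc(=O)o1`, gives 4.93 uM.

Compound 2 holds the lowest of the two numbers, but its nearest neighbour is compound 1, and the step of a 1.1-fold lower number from compound 1 to compound 2 (0.03 log units; within the scatter) shows that the two values cannot be told apart. Compound 3, `COc1ccc(Nc2cc(/C=C/c3ccccc3)oc(=O)c2)cc1`, has not yet been measured. It differs from compound 2 by 2-phenylethenyl in place of pentyl on an aromatic carbon, placed next to the ring oxygen of the shared core. Going by the values given here, only the step from compound 1 to compound 2 bears on this change, and that step exchanged one saturated group for another without effect beyond the scatter; no measured compound carries an aromatic ring at this position. On that basis the group is expected to be tolerated, and the step of a 1.1-fold lower number from compound 2 to compound 3 (0.04 log units; within the scatter) is estimated to stay within the scatter. Compound 3 is therefore expected to give about 4.5 uM, with a likely range from 1.5 uM to 13 uM.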

Compound 3, concentration for half-maximal effect: 0.083 uM
Compound 3: the middle estimate sits 54-fold (1.73 log units) above what was measured, and the stated range ends above it.
By their numbers in this assay, from the lowest: compound 3; then compounds 2 and 1 (each within the scatter of the next).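

In this assay, the aromatic carbon next to the ring oxygen proved far from indifferent to the group it carries: 2-phenylethenyl in place of pentyl gives a large gain (a 59-fold lower number from compound 2 to compound 3 (1.77 log units; beyond the scatter)). The same group in place of cyclohexyl gives a gain of similar size (a 64-fold lower number from compound 1 to compound 3 (1.80 log units; beyond the scatter)), although pentyl and cyclohexyl could not be told apart from each other (a 1.1-fold lower number from compound 1 to compound 2 (0.03 log units; within the scatter)). Compounds 1 and 2 had therefore hidden how much this position can matter, and only the group with an aromatic ring and a double bond revealed it.

From the compounds shown here alone, whether the gain goes with the ring, the double bond or both stays open, and a 2-phenylethyl group or a plain phenyl at this position would help to separate them. Nothing in the available data explains why this exchange has so large an effect.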